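A few compounds are considered here, and "the series" means these few. Any claim that something is new, unique, unknown or untested is made for them only; others in the source may bear on it.

Measured so far in an assay on isolated protein for agonist activity at Bile acid receptor (Homo sapiens), read by FRET; a lower number here means that less compound is needed, a higher number that more compound is needed for the effect:
- compound 1 `CC(C)c1onc(-c2c(Cl)cccc2Cl)c1COc1ccc(N(C)Cc2cccc(C(=O)O)c2)c(C(F)(F)F)n1` gives 12 nM
- compound 2 `CC(C)c1onc(-c2c(Cl)cccc2Cl)c1COc1ccc(N(C)Cc2ccc(OCC(=O)O)cc2)c(C(F)(F)F)n1` gives 35 nM
- compound 3 `CN(Cc1cccc(C(=O)O)c1)c1ccc(OCc2c(-c3c(Cl)cccc3Cl)noc2C2CC2)nc1C(F)(F)F` gives 3 nM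

Compound 3 stands lowest of the three numbers; the step of a 4.0-fold lower number from compound 1 to compound 3 (0.60 log units; beyond the scatter) sets it apart from compound 1, and its gap to compound 2 is wider still. Compound 4 `CN(Cc1ccc(C(=O)O)cc1)c1ccc(OCc2c(-c3c(Cl)cccc3Cl)noc2C2CC2)nc1C(F)(F)F` keeps the core of compound 3 and changes only the acid-bearing arm: 4-carboxyphenyl in place of 3-carboxyphenyl on a saturated chain carbon bound to a nitrogen on an aromatic ring. Going by the values given here, no measured step swaps these two carboxyphenyl groups directly. The nearest guide is the arm change a 2.9-fold higher number from compound 1 to compound 2 (0.46 log units; beyond the scatter), where the acid moved away from its place on the 3-carboxyphenyl and the number rose modestly. A similar, modest rise is therefore expected, a 2.3-fold higher number from compound 3 to compound 4 (0.37 log units; beyond the scatter). Compound 4 is estimated at 7 nM, within 3 nM to 20 nM.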

Compound 4, half-maximal effective concentration: 12 nM
Compound 4: middle estimate off by 1.7-fold (0.23 log units), on the low side; low and high end bracket the measured number.
By their numbers in this assay, from the lowest: compound 3; then compounds 1 and 4 (each within the scatter of the next); then compound 2.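

On the cyclopropyl compounds, 4-carboxyphenyl in place of 3-carboxyphenyl gives a 4.0-fold higher number from compound 3 to compound 4 (0.60 log units; beyond the scatter). The two groups have the same atoms, so this isolates where the acid sits on the ring, which the earlier arm change from 3-carboxyphenyl to 4-(carboxymethoxy)phenyl could not do. No measurement available here explains the step.

From the compounds shown here alone, whether the same swap gives a step of similar size on the isopropyl core remains open. So does the outcome of replacing the carboxylic acid on this arm with a tetrazole or a primary amide.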